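This account rests on a few compounds, and the source may have more. Where it says the series, first, only, none or still open, it means among the compounds named here.

Among the compounds with values here, in a functional assay on A549 cells (Homo sapiens) for cytotoxicity, read by MTT assay, with a stated time of 72 h (a higher number here means a weaker inhibitor, a lower number a stronger inhibitor), compound 1 `O=C(CN1CCN(c2nnc(Cc3ccncc3)c3ccccc23)CC1)Nc1ccc(Br)cc1` gives 2710 nM, while compound 2 `O=C(CN1CCN(c2nnc(Cc3ccncc3)c3ccccc23)CC1)Nc1c(F)cccc1F` gives 54400 nM, the higher of the two numbers so far. The next structure is compound 3 `O=C(CN1CCN(c2nnc(Cc3ccncc3)c3ccccc23)CC1)Nc1ccc(F)c(F)c1`, and the change is 3,4-difluorophenyl in place of 2,6-difluorophenyl on an amide-type nitrogen. Within the data shown here, one measured step bears on this, a 20-fold higher number from compound 1 to compound 2 (1.30 log units; beyond the scatter), which is large, lies beyond the scatter and changes the group on that same nitrogen. Among the measured compounds shown here, that step starts from 4-bromophenyl rather than 3,4-difluorophenyl, so it is only a rough guide, and no measured compound carries the new group. A move to a lower number in this assay is expected, covering part of the gap set by that step, and the estimated change is a 6.0-fold lower number from compound 2 to compound 3 (0.78 log units; beyond the scatter). For compound 3 the estimated value is 9000 nM, with an expected range of 2500 nM to 32000 nM.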

Compound 3, half-maximal inhibitory concentration: 3790 nM
For compound 3 the middle estimate is 2.4-fold (0.38 log units) above the measured one; low and high end bracket the measured number.
By their numbers in this assay, from the lowest: compounds 1 and 3 (each within the scatter of the next); then compound 2.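

In this assay, moving the two fluorines on the phenyl group at the amide-type nitrogen, with the atoms unchanged, gives a 14-fold lower number from compound 2 to compound 3 (1.16 log units; beyond the scatter) and so shows that this position responds to the arrangement of the substituents and not only to which atoms are present. The earlier drop therefore cannot be read as applying to difluorophenyl groups in general, since it is confined here to the 2,6-difluorophenyl group. Replacing 4-bromophenyl gives a 1.4-fold higher number from compound 1 to compound 3 (0.15 log units; within the scatter) and leaves 3,4-difluorophenyl and 4-bromophenyl unseparated, and no available data explain the effect of the fluorine arrangement.

Still open, on these data alone, is how a single fluorine, as in 2-fluorophenyl or 4-fluorophenyl, would compare with these groups. Also open, as far as these compounds go, is whether a non-halogen group on the phenyl ring, such as methoxy or an amine, would be tolerated at this position.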